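Replacing a Chlorophenyl with a Pyridyl on the Alkyne

The compounds below may be only part of what the source reports. "The series", "measured", "known", "first", "only" and "open" are said of these compounds alone.

Compound 1 `Cc1ccccc1C#Cc1ccc2c(n1)CCN(C1CCCCC1)C2=O` in an assay on HEK293 cells for displacement of a labelled ligand from metabotropic glutamate receptor 5 (Homo sapiens), with a stated time of 2 h (a lower number here means a stronger inhibitor, a higher number a weaker inhibitor), gives > 32000 nM, which is a limit of the assay.
Compound 2 `O=C1c2ccc(C#Cc3cccc(Cl)c3)nc2CCN1C1CCCCC1` in this assay gives 12000 nM.

Among the measured compounds shown here, compound 2 thus holds the only numerical value so far; the other result is a limit. For the measured compounds named here, the one measured step, an at least 2.6-fold lower number from compound 1 to compound 2 (0.42 log units; beyond the scatter), concerns the aryl group on the triple-bonded carbon, as does the change to compound 3 `O=C1c2ccc(C#Cc3cccnc3)nc2CCN1C1CCCCC1`: pyridin-3-yl in place of 3-chlorophenyl on a triple-bonded carbon. Since that step was only modest and partly rests on a limit (the limit of > 32000 nM in this assay, at which 1 of the 2 values shown sits), a small change, if any, is expected, a 1.7-fold higher number from compound 2 to compound 3 (0.22 log units; within the scatter). Compound 3 is therefore estimated at 20000 nM, within 6000 nM to 40000 nM.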

Compound 3, inhibition constant: 15600 nM
Compound 3: the middle estimate sits 1.3-fold (0.11 log units) above what was measured; measured number inside the range.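

Pyridin-3-yl in place of 3-chlorophenyl on a triple-bonded carbon gives a 1.3-fold higher number from compound 2 to compound 3 (0.11 log units; within the scatter) in this assay, so swapping the chlorine-bearing carbon ring for a ring with a hydrogen-bond acceptor leaves no readable change at this position. Pyridin-3-yl in place of 2-methylphenyl gives an at least 2.0-fold lower number from compound 1 to compound 3 (0.31 log units; beyond the scatter), the same direction as the earlier step to the 3-chlorophenyl compound. This comparison rests on a limit rather than a number: the limit of > 32000 nM in this assay, at which 1 of the 3 values shown sits.

The compounds shown leave open how pyridin-2-yl or pyridin-4-yl would behave at this position. They also leave open whether an unsubstituted phenyl would give a different number.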